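This account rests on a few compounds, and the source may have more. Where it says the series, first, only, none or still open, it means among the compounds named here.

Compound 1 `Cc1ccccc1-n1nncc1CN1C(=O)C2(C(C#N)=C(N)Oc3c2c2nc4ccccc4nc2c2ccccc32)c2ccccc21`: in a functional assay on HCT-116 cells (Homo sapiens) for antiproliferative activity, read by MTT assay, with a stated time of 48 h (a higher number here means a weaker inhibitor, a lower number a stronger inhibitor), compound 1 gives > 50000 nM, a limit of the assay.
Compound 2 `N#CC1=C(N)Oc2c(N)cc3nc4ccccc4nc3c2C12C(=O)N(Cc1cnnn1-c1ccc(F)cc1)c1ccccc12`: in this assay compound 2 gives > 50000 nM, a limit of the assay.

Compound 2 stands at a limit, not at a number. The only other measurement shown is the same kind of limit, so both values sit at the limit of > 50000 nM in this assay, at which 2 of the 2 values shown sit, and neither compound can be placed above or below the other. For the measured compounds named here, no step between measured compounds is available to draw on.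

Compound 3 `N#CC1=C(N)Oc2c(N)cc3nc4ccccc4nc3c2C12C(=O)N(Cc1cnnn1-c1cc(Cl)ccc1Cl)c1ccccc12` is the next compound. It differs from compound 2 at the aromatic nitrogen of the five-membered ring: 2,5-dichlorophenyl in place of 4-fluorophenyl on an aromatic nitrogen.

Going by the values given here, with both measured compounds at the limit, there is no measured step from which a direction could be read, and the change here is confined to the group on that ring nitrogen. For compound 3 the expectation is that the assay will again report only a limit, and the estimated step of a number no higher from compound 2 to compound 3 (the limit leaves the size open) is none beyond the usual scatter. Compound 3 is therefore estimated at 50000 nM in this assay, expected to lie between 20000 nM and 100000 nM.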

Compound 3, half-maximal inhibitory concentration: > 50000 nM
Compound 3 ended at the assay's limit (the forecaster's own chance of this, stated with the estimate: 75%); the middle value lies on the limit itself.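

No step can be read from compound 2 to compound 3 in this assay, and neither compound can be placed above the other, as each value is a limit and not a number: the limit of > 50000 nM in this assay, at which 3 of the 3 values shown sit.

The compounds shown leave open how far past the limit each lies, and whether any group on that ring nitrogen would give a measurable value.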